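This account rests on a few compounds, and the source may have more. Where it says the series, first, only, none or still open, it means among the compounds named here.

Compound 1 `COc1ccccc1NC(=S)N/N=C/c1ccc2ccccc2n1`: in a functional assay on SGC-7901 cells (Homo sapiens) for antiproliferative activity, read by sulforhodamine B assay, with a stated time of 72 h (a lower number here means a stronger inhibitor, a higher number a weaker inhibitor), compound 1 gives > 100000 nM, which is a limit of the assay and not a number.
Compound 2 `CN(C)C(=S)N/N=C/c1cc2cccnc2s1`: in this assay compound 2 gives 21400 nM.
Compound 3 `COc1ccc(C)cc1NC(=S)N/N=C/c1ccc2ccccc2n1`: in this assay compound 3 gives > 100000 nM, again a limit rather than a number.

Compound 1 therefore stands at the edge of what this assay can report, and it is not alone there, since (the limit of > 100000 nM in this assay, at which 2 of the 3 values shown sit). Among the measured compounds shown here, compound 2 rests on a different core, so its value shows only that a measurable number is possible; no step connects it to compound 1. For the measured compounds named here, the one step on the shared core, a step that the two limits leave unreadable from compound 1 to compound 3, is a move from one limit to another and tells nothing about its size.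

Compound 4 `FC(F)(F)c1ccccc1NC(=S)N/N=C/c1ccc2ccccc2n1` differs from compound 1 in one place: trifluoromethyl in place of methoxy on an aromatic carbon. Going by the values given here, no measured step concerns a trifluoromethyl at this position, and the only step on this core is unreadable, so there is no basis to expect movement in either direction in this assay. Compound 4 is expected to sit where compound 1 sits, that is at the limit, with an estimate of 100000 nM spanning 30000 nM to 300000 nM. The step from compound 1 to compound 4 is thus expected to be a number no higher from compound 1 to compound 4 (the limit leaves the size open), nothing beyond the scatter.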

Compound 4, half-maximal inhibitory concentration: 20700 nM
The estimate for compound 4 lay 4.8-fold (0.68 log units) above the measured number; the whole stated range lies above it.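

On the shared core, trifluoromethyl in place of methoxy, on an aromatic carbon ortho to a large group, gives an at least 4.8-fold lower number from compound 1 to compound 4 (0.68 log units; beyond the scatter) in this assay. Among the compounds shown here, this is the first readable step on this core, since the earlier step between compound 1 and compound 3 ran from one limit to another and could not be read. Compound 4, at 20700 nM, shows that a change at this one position can bring the core of compound 1 into the range where the assay reports a number. The step has a minimum size but no known full size, because the value for compound 1 is only a limit, and that limit still applies to part of the series: the limit of > 100000 nM in this assay, at which 2 of the 4 values shown sit.

A single pair cannot show whether the gain follows from the arrival of trifluoromethyl or the loss of methoxy, nor whether a single fluorine, an amine or a carboxylic acid on the same carbon would also give a measurable number. It also remains open whether the methyl group that separates compound 3 from compound 1 would change the value of compound 4, as the compounds shown include no such pair on the trifluoromethyl side.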